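The source may report more compounds than this note shows. Statements on the series, on what has been measured and on what is new or still open speak of the compounds shown alone.

Of the compounds shown here, three built on a shared core have been measured in an assay on membranes from brain for displacement of a labelled ligand from adenosine receptor A1 (Rattus norvegicus), read by radioligand binding; a lower number here means a stronger inhibitor, a higher number a weaker inhibitor. Compound 1 `O=C1/C(=C/c2ccc(O)c(O)c2)Cc2c(O)cccc21` gives 435 nM in this assay. Compound 2 `COc1cccc2c1C/C(=C\c1ccc(N(C)C)cc1)C2=O` reports only a limit in this assay, > 100000 nM, and that value is the limit of > 100000 nM in this assay, at which 1 of the 3 values shown sits. Compound 3 `COc1cccc2c1C/C(=C\c1cccc(O)c1)C2=O` gives 41 nM in this assay, the lower of the two numbers reported; its nearest neighbour is compound 1, whose number is higher by a margin beyond the usual scatter.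

Compound 4 `COc1cccc2c1C/C(=C\c1ccccc1)C2=O` has not yet been measured in this assay. It differs from compound 3 in one place: hydrogen in place of hydroxy on an aromatic carbon, the hydroxy removed from the carbon meta to a large group. Among the measured compounds shown here, no pair of measured compounds differing in a single place is available, so the size of this step can only be expected, not read. The author expects compound 4 to be weaker than compound 3 in this assay, by a step beyond the scatter. For compound 4 he estimates 300 nM in this assay, with a range from 60 nM to 1500 nM. This estimate means an expected step of a 7.3-fold higher number from compound 3 to compound 4 (0.86 log units; beyond the scatter).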

Compound 4, inhibition constant: 1650 nM
For compound 4 the middle estimate is 5.5-fold (0.74 log units) below the measured one; the measured number lies above the stated range.
By their numbers in this assay, from the lowest: compound 3; then compound 1; then compound 4. At a limit, above all of these: compound 2.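

In this assay, the hydroxy of compound 3 now proves to matter on its own: replacing it with hydrogen gives a 40-fold higher number from compound 3 to compound 4 (1.60 log units; beyond the scatter), so this single group accounts for a large part of the binding strength seen in compound 3. Compound 2 reports only a limit: the limit of > 100000 nM in this assay, at which 1 of the 4 values shown sits. Hydrogen in place of dimethylamino, on a different aromatic carbon from the hydroxy, gives an at least 60-fold lower number from compound 2 to compound 4 (1.78 log units; beyond the scatter), so the unsubstituted ring of compound 4 sits between the two substituted ones, with one change lowering the number and the other raising it.

Going by these compounds, how an amino group, a fluorine or a carboxylic acid on the carbon that carries the hydroxy would compare remains open. Also open, on these data alone, is what the hydroxy would do on other carbons of this ring.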